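Aryl variation on the amide carbonyl of the shared core

The compounds below may be only part of what the source reports. "The series", "measured", "known", "first", "only" and "open" are said of these compounds alone.

Compound 3 `CN1[C@@H]2c3[nH]c4ccccc4c3C[C@H]1[C@H](C#N)N1[C@@H](CNC(=O)c3cccc4c3CCCC4)c3[nH]c4ccccc4c3C[C@@H]21` gives 540 nM in a functional assay on HepG2 cells (Homo sapiens) for cytotoxicity, read by MTT assay, with a stated time of 72 h; on this read-out higher numbers stand for weaker inhibition and lower numbers for stronger inhibition; among the three measured compounds this is the second highest number. Compound 1 `CN1[C@@H]2c3[nH]c4ccccc4c3C[C@H]1[C@H](C#N)N1[C@@H](CN3C(=O)c4ccccc4C3=O)c3[nH]c4ccccc4c3C[C@@H]21` gives 20 nM in this assay, and compound 2 `CCc1ccc(C(=O)NC[C@H]2c3[nH]c4ccccc4c3C[C@H]3[C@H]4c5[nH]c6ccccc6c5C[C@@H]([C@H](C#N)N23)N4C)cc1` gives 570 nM. The step of a 29-fold higher number from compound 1 to compound 2 (1.45 log units; beyond the scatter) is large and sets compound 1 apart from the two amides, whereas the step of a 1.1-fold lower number from compound 2 to compound 3 (0.02 log units; within the scatter) lies within the scatter, so compound 2 and compound 3 cannot be told apart on these numbers.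

Compound 4 `CN1[C@@H]2c3[nH]c4ccccc4c3C[C@H]1[C@H](C#N)N1[C@@H](CNC(=O)c3cc4ccccc4[nH]3)c3[nH]c4ccccc4c3C[C@@H]21` differs from compound 3 by 1H-indol-2-yl in place of 1,2,3,4-tetrahydronaphthalen-5-yl on a carbonyl carbon. Going by the values given here, the one measured step that bears on this change is the earlier exchange of the aryl group on the same carbonyl carbon, a 1.1-fold lower number from compound 2 to compound 3 (0.02 log units; within the scatter), which stayed within the scatter. The step from compound 1 to compound 2 concerns the replacement of a whole group on a chain carbon and does not bear on an aryl swap at the carbonyl. Among the compounds with values here, with only one relevant step, and that one flat, the expectation for compound 4 in this assay is a step of no size beyond the scatter, written as a 1.1-fold lower number from compound 3 to compound 4 (0.03 log units; within the scatter). Compound 4 is thus estimated at 500 nM, with a range from 180 nM to 1500 nM.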

Compound 4, half-maximal inhibitory concentration: 440 nM
Compound 4: the middle estimate sits 1.1-fold (0.06 log units) above what was measured; the measured number falls inside the stated range.
By their numbers in this assay, from the lowest: compound 1; then compounds 4, 3 and 2 (each within the scatter of the next).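

Notes on the aryl group on the carbonyl carbon: in this assay, 1H-indol-2-yl in place of 1,2,3,4-tetrahydronaphthalen-5-yl gives a 1.2-fold lower number from compound 3 to compound 4 (0.09 log units; within the scatter), and 1H-indol-2-yl in place of 4-ethylphenyl gives a 1.3-fold lower number from compound 2 to compound 4 (0.11 log units; within the scatter). The flat result now extends from two aryl groups made of carbon only to one with a five-membered aromatic ring and a hydrogen-bond donor, so compounds 2, 3 and 4 cannot be told apart on these numbers. This third aryl group also leaves the large gap to the group on the chain carbon of compound 1 in place, with a 22-fold higher number from compound 1 to compound 4 (1.34 log units; beyond the scatter), so compound 1 remains set apart from all three amides.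

Open, going by these compounds, is whether a non-aromatic group such as cyclohexyl, a basic amine such as piperidine, or an aryl group bearing a carboxylic acid on this carbonyl carbon would move the number beyond the scatter, and whether any amide here can approach compound 1. No supporting measurement is available to explain either the flat aryl series or the gap to compound 1.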